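A few compounds are considered here, and "the series" means these few. Any claim that something is new, unique, unknown or untested is made for them only; others in the source may bear on it.

Compounds measured so far:
compound 1, `Cc1ccc(C(=O)NC(=S)N2CCc3c(OCCCCCOc4ccc(Cl)cc4)cccc32)cc1` — > 50000 nM
compound 2, `O=C(NC(=S)N1CCc2c(OCCCCCOc3ccc(Cl)cc3)cccc21)c1ccno1` — 37100 nM
Not yet measured: compound 3, `O=S(=O)(NC(=S)N1CCc2c(OCCCCCOc3ccc(Cl)cc3)cccc21)c1ccccc1`

In an ADME assay on Huh-7 cells (Homo sapiens) for cytotoxicity (on this read-out lower numbers stand for higher toxicity in this test and higher numbers for lower toxicity in this test), compound 1 gives > 50000 nM, which is a limit of the assay and not a number. Compound 2 gives 37100 nM in this assay, the only number shown. Going by the values given here, the one further value shown, that of compound 1, is a limit. Among the compounds with values here, the single measured step, an at least 1.3-fold lower number from compound 1 to compound 2 (0.12 log units; that floor lies within the scatter), changed the acyl group on the nitrogen next to the thiocarbonyl carbon, and it lies within the scatter, with one of the two values sitting at the limit of > 50000 nM in this assay, at which 1 of the 2 values shown sits.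

Compound 3 differs from compound 2 by phenylsulfonyl in place of (1,2-oxazol-5-yl)carbonyl on an amide-type nitrogen. Within the data shown here, the one step that bears on it is the change of the group on that same nitrogen from compound 1 to compound 2, and it stayed within the scatter. Compound 3 is therefore expected to move by no step beyond the scatter, a 1.1-fold higher number from compound 2 to compound 3 (0.03 log units; within the scatter). Compound 3 is estimated at 40000 nM, between 15000 nM and 100000 nM, with a fair chance that this assay reports only a limit.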

Compound 3, half-maximal cytotoxic concentration: > 50000 nM
Compound 3 gave a limit, no number (the forecaster's own chance of this, stated with the estimate: 45%); middle value at least 1.2-fold (0.09 log units) from the limit.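

On the amide-type nitrogen whose other neighbour is the thiocarbonyl carbon, the exchange of (1,2-oxazol-5-yl)carbonyl for phenylsulfonyl gives, in this assay, an at least 1.3-fold higher number from compound 2 to compound 3 (0.12 log units; that floor lies within the scatter), so replacing the carbonyl link with a sulfonyl link at this position produces no readable step beyond the scatter. Compound 3 gives > 50000 nM, which is a limit of the assay and not a number. The step from compound 1 to compound 3 cannot be read, and the change from compound 2 to compound 3 has only a floor and no measured size: the limit of > 50000 nM in this assay, at which 2 of the 3 values shown sit.

The compounds shown leave open how far the true values of compound 1 and compound 3 lie beyond that limit, and so whether the sulfonyl and carbonyl groups on this nitrogen differ at all in this assay. They also leave open what a methylsulfonyl group on this nitrogen, or a carboxylic acid or an amine on the phenyl ring of the phenylsulfonyl group, would give, and whether any such group would bring the value clear of the limit.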